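The source may hold more compounds than are shown below. What is called first, only, known or untested is meant among the compounds shown, and "the series" means these compounds.

Compound 1 `CCN(CC)c1cc2[nH]c(C3CCCCC3)nc2cc1NC(=O)c1cnccn1`, compound 2 `CCCCCC(=O)Nc1cc2nc(C3CCCCC3)[nH]c2cc1N(CC)CC` and compound 3 `CCCCOC(=O)Nc1cc2nc(C3CCCCC3)[nH]c2cc1N(CC)CC` share one core and differ in the acyl group on its amide or carbamate nitrogen. Their read-out here is an ADME assay on Vero cells (Chlorocebus sabaeus) for cytotoxicity, read by resazurin assay, with a stated time of 3 days; a lower number here means a stronger inhibitor, a higher number a weaker inhibitor. Compound 1 gives > 100 ug/mL, which is a limit and not a number. Compound 3 gives > 100 ug/mL, which is also a limit and not a number. For compound 2 the result is "not determined" (no result reported). Compound 3 therefore stands at the limit of > 100 ug/mL in this assay, at which 2 of the 3 values shown sit.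

Compound 4 `CCCC(C)OC(=O)Nc1cc2nc(C3CCCCC3)[nH]c2cc1N(CC)CC` keeps everything in compound 3 except that butoxy becomes 1-methylbutoxy: methyl in place of hydrogen on a saturated chain carbon bound to an oxygen next to a carbonyl group and a saturated chain carbon. Among the compounds with values here, the one measured step that bears on this change is a step that the two limits leave unreadable from compound 1 to compound 3, and it offers no size to carry over. It does show that replacing pyrazin-2-yl with butoxy on the carbonyl carbon leaves both compounds reported as limits. With compound 3 at the limit of > 100 ug/mL in this assay, at which 2 of the 3 values shown sit, no step beyond the scatter is expected in this assay, in either direction. The expected step is a number no higher from compound 3 to compound 4 (the limit leaves the size open), an estimate and not a measurement. The assay may well report only a limit again. Compound 4 is estimated at 100 ug/mL, with an expected range of 50 ug/mL to 200 ug/mL.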

Compound 4, half-maximal inhibitory concentration: > 100 ug/mL
Compound 4: a limit, no number; the forecaster's own chance of this, stated with the estimate: 80%; the middle value lies on the limit itself.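

Compound 1, compound 3 and compound 4 are all reported in this assay as a limit and not as a number, so the steps between them cannot be read: the limit of > 100 ug/mL in this assay, at which 3 of the 4 values shown sit. The compounds shown leave open how far each lies past that limit, and whether 1-methylbutoxy in place of butoxy changes the value at all.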